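A few compounds are considered here, and "the series" means these few. Any claim that something is new, unique, unknown or untested is made for them only; others in the source may bear on it.

Measured so far:
compound 1 `O=C1N=C(Nc2ccc(O)cc2)S/C1=C\c1ccc(Cl)cc1`: 490 nM
compound 2 `O=C1N=C(Nc2ccc(O)cc2)S/C1=C\c1ccc(F)cc1`: 562 nM
compound 3 `O=C1N=C(Nc2cccc(O)c2)S/C1=C\C(Cl)=C/c1ccc([N+](=O)[O-])cc1`: 955 nM

In a functional assay on OVCAR-3 cells (Homo sapiens) for cytotoxicity (on this read-out lower numbers stand for stronger inhibition of growth and higher numbers for weaker inhibition of growth), compound 1 has the lowest of the three numbers, though its gaps to compound 2 and compound 3 both lie within the scatter. Among the compounds with values here, the only single-point step seen, a 1.1-fold higher number from compound 1 to compound 2 (0.06 log units; within the scatter), comes from fluoro in place of chloro on an aromatic carbon and is too small to count as a change. Compound 3 differs from compound 1 in more than one place, so its value alone is shown.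

Compound 4 `O=C1N=C(Nc2cccc(O)c2)S/C1=C\c1ccc(Cl)cc1` differs from compound 1 by 3-hydroxyphenyl in place of 4-hydroxyphenyl on an amine nitrogen. Within the data shown here, no measured step tests this change directly, and nothing seen here suggests a move beyond the scatter. Compound 4 is therefore expected near 550 nM, between 250 nM and 1200 nM. This means an expected step of a 1.1-fold higher number from compound 1 to compound 4 (0.05 log units; within the scatter).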

Compound 4, concentration for total growth inhibition: 2750 nM
Compound 4: middle estimate off by 5.0-fold (0.70 log units), on the low side; the measured number lies above the stated range.
By their numbers in this assay, from the lowest: compounds 1, 2 and 3 (each within the scatter of the next); then compound 4.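

Swapping 4-hydroxyphenyl for 3-hydroxyphenyl on an amine nitrogen gives a 5.6-fold higher number from compound 1 to compound 4 (0.75 log units; beyond the scatter) in this assay, even though the two groups have the same atoms and the same counts of hydrogen-bond donors and acceptors. Unlike fluoro in place of chloro, this change moves the number beyond the scatter, so at this position, on the core of compound 1, the way the same atoms are joined matters. No measurement shown here explains the difference. On these data alone, whether a 3-methoxyphenyl or 3-aminophenyl group would behave like 3-hydroxyphenyl remains open, as does whether the same swap would have a similar effect on compound 2.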